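From pyridin-3-yl to pyridin-4-yl on the amine nitrogen

The compounds below may be only part of what the source reports. "The series", "measured", "known", "first", "only" and "open" are said of these compounds alone.

- Compound 1 `CC(=O)NC[C@H]1CN(c2ccc(OC[C@H](O)CNc3ccccc3)c(F)c2)C(=O)O1` gives 296000 nM in a physicochemical assay for solubility, read by HPLC; on this read-out lower numbers stand for lower solubility and higher numbers for higher solubility
- Compound 2 `CC(=O)NC[C@H]1CN(c2ccc(OC[C@@H](O)CNc3ccccn3)c(F)c2)C(=O)O1` gives 22200000 nM in this assay
- Compound 3 `CC(=O)NC[C@H]1CN(c2ccc(OC[C@H](O)CNc3cccnc3)c(F)c2)C(=O)O1` gives 10100000 nM in this assay

Compound 3 stands second of these three, with compound 2 above it and compound 1 far below. Compound 4 `CC(=O)NC[C@H]1CN(c2ccc(OC[C@@H](O)CNc3ccncc3)c(F)c2)C(=O)O1` keeps the shared core and differs by 1-hydroxy-2-((pyridin-4-yl)amino)ethyl in place of 1-hydroxy-2-((pyridin-3-yl)amino)ethyl on a saturated chain carbon bound to an oxygen on an aromatic ring, the same atoms joined differently. The large steps, a 75-fold higher number from compound 1 to compound 2 (1.88 log units; beyond the scatter) and a 34-fold higher number from compound 1 to compound 3 (1.53 log units; beyond the scatter), both replaced a phenyl, which compound 3 no longer carries. The closer guide is the exchange of one pyridine for another, a 2.2-fold lower number from compound 2 to compound 3 (0.34 log units; beyond the scatter), a modest step. A similarly small change is therefore expected here, and the estimated step is a 1.6-fold higher number from compound 3 to compound 4 (0.20 log units; within the scatter), slightly upward. In this assay compound 4 is estimated at 16000000 nM, with an expected range from 5000000 nM to 45000000 nM.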

Compound 4, solubility: 17700000 nM
Compound 4: middle estimate off by 1.1-fold (0.04 log units), on the low side; low and high end bracket the measured number.
By their numbers in this assay, from the lowest: compound 1; then compounds 3, 4 and 2 (each within the scatter of the next, the first and the last beyond it).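

Compound 4 lies within the scatter of both other pyridines, with a 1.8-fold higher number from compound 3 to compound 4 (0.24 log units; within the scatter) and a 1.3-fold lower number from compound 2 to compound 4 (0.10 log units; within the scatter) in this assay, so 1-hydroxy-2-((pyridin-4-yl)amino)ethyl gives a number much like theirs. It also keeps the large distance from the phenyl compound, with a 60-fold higher number from compound 1 to compound 4 (1.78 log units; beyond the scatter) as the step from 2-anilino-1-hydroxyethyl. The compounds shown leave open whether pyrimidin-5-yl on the amine nitrogen, or a pyridin-4-yl carrying a methyl group, would stay at this level. Nothing available explains why the three pyridines give such similar numbers.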